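This account rests on a few compounds, and the source may have more. Where it says the series, first, only, none or still open, it means among the compounds named here.

The compounds here share one core, and the interest is in what happens at one position when a group is swapped. Compound 1 `Nc1nc(NC2CCCC2)c2ncn(/C=C3/CC3(CO)CO)c2n1` was tested in an ADME assay on MOLT-3 cells (Homo sapiens) for cytotoxicity, with a stated time of 7 days (a lower number here means that less compound is tolerated, a higher number that more compound is tolerated), and compound 1 gave > 20000 nM, which is a limit of the assay rather than a number. That reading sits at the limit of > 20000 nM in this assay, at which 1 of the 2 values shown sits, and it is the only measured result in the set.

Compound 2 `CC(C)CNc1nc(N)nc2c1ncn2/C=C1/CC1(CO)CO` carries an isobutylamino group at the same position, but in this assay compound 2 gave "not determined" (no result reported), so it stands without a number of its own. It can only be placed beside the limit seen for compound 1.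

Compound 3 `CCCCSc1nc(N)nc2c1ncn2/C=C1/CC1(CO)CO` is the compound yet to be measured. The change from compound 2 to compound 3 is butylsulfanyl in place of isobutylamino on an aromatic carbon. For the measured compounds named here, with no measured step anywhere in the set, there is nothing to say about size or direction; the expectation is simply that compound 3 behaves much like compound 1. Compound 3 is therefore estimated at 20000 nM in this assay, with a range from 5000 nM to 100000 nM.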

Compound 3, half-maximal cytotoxic concentration: > 20000 nM
Compound 3 was reported as a limit (the forecaster's own chance of this, stated with the estimate: 80%); the middle value lies on the limit itself.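

Compound 1 and compound 3 each give only a limit of the assay rather than a number, so no step from one to the other can be read: the limit of > 20000 nM in this assay, at which 2 of the 3 values shown sit.

The compounds shown leave open at what concentration any of them would become toxic to the cells in this assay, and where compound 2 stands.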